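Lengthening the hydroxy-bearing chain on a shared core

The source may hold more compounds than are shown below. What is called first, only, known or untested is meant among the compounds shown, and "the series" means these compounds.

Compound 1 `CCCCCCCc1cn(C(c2ccccc2)c2cc3cc(Br)ccc3nc2OC)nn1`: 4.42%
Compound 2 `COc1nc2ccc(Br)cc2cc1C(c1ccccc1)n1cc(CCO)nn1`: 15.5%

In an ADME assay on PC-3 cells (Homo sapiens) for cytotoxicity, read by sulforhodamine B assay, with a stated time of 48 h, tested at 10 uM (on this read-out higher numbers stand for more inhibition at the one concentration tested (going by the name of the read-out) and lower numbers for less inhibition), compound 2 gives 15.5%, the higher of the two numbers seen. Compound 1 gives 4.42%. Compound 3 `COc1nc2ccc(Br)cc2cc1C(c1ccccc1)n1cc(CCCCCO)nn1` differs from compound 2 by 3-hydroxypropyl in place of hydroxy on a saturated chain carbon, two bonds along the chain from an aromatic carbon. Among the compounds with values here, the one measured step, a number 11.1 percentage points higher from compound 1 to compound 2 (beyond the scatter), exchanged a long chain without a hydroxy for a short chain carrying one. Compound 3 keeps the hydroxy but lengthens the chain, so a modest fall toward compound 1 is expected, smaller than that step. Compound 3 is therefore estimated at 10%, within 0% to 22%, a step of a number 5.5 percentage points lower from compound 2 to compound 3 (within the scatter).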

Compound 3, a percentage reported as inhibition, at one concentration (the size of the read-out at that concentration, not a potency): 12.9%
Estimate against measurement, compound 3: 2.9 percentage points below; low and high end bracket the measured number.
By their numbers in this assay, from the lowest: compounds 1, 3 and 2 (each within the scatter of the next, the first and the last beyond it).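

In this assay, putting 3-hydroxypropyl in place of hydroxy gives a number 2.6 percentage points lower from compound 2 to compound 3 (within the scatter), so on this saturated chain carbon the hydroxy-bearing chain can be lengthened with no readable change. Against the chain without a hydroxy, the result is a number 8.5 percentage points higher from compound 1 to compound 3 (within the scatter), so compound 3 cannot be told apart from either compound 1 or compound 2. Nothing available here explains these numbers. Still open, on these data alone, is whether a longer chain, or an amine or a carboxylic acid in place of the hydroxy, would read differently from compound 2.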